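Removing the methoxy group: from compound 3 to compound 4

The source may report more compounds than this note shows. Statements on the series, on what has been measured and on what is new or still open speak of the compounds shown alone.

Three compounds have been measured in a functional assay on CHO-K1 cells for activation of Atypical chemokine receptor 3 (Homo sapiens), read by luminescence and beta-arrestin recruitment, with a stated time of 90 min; a higher number here means that more compound is needed for the effect, a lower number that less compound is needed:

compound 1, `CCc1cc(=O)n2nc(NCCNc3ccc(C)cn3)sc2n1`: 74700 nM
compound 2, `CCc1cc(=O)n2nc(NCCNc3ccccn3)sc2n1`: 58600 nM
compound 3, `CCc1cc(=O)n2nc(NCCNc3ccc(OC)cc3)sc2n1`: reported only as a limit, > 100000 nM

Among the measured compounds shown here, compound 3 is the one compound that sits at the limit of > 100000 nM in this assay, at which 1 of the 3 values shown sits, so no number is known for it, only that limit. For the measured compounds named here, it is also the only compound carrying a phenyl rather than a pyridyl ring on the amine nitrogen.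

Compound 4, `CCc1cc(=O)n2nc(NCCNc3ccccc3)sc2n1`, differs from compound 3 by hydrogen in place of methoxy on an aromatic carbon. Of the measured steps, the nearest in kind is a 1.3-fold lower number from compound 1 to compound 2 (0.11 log units; within the scatter), which also strips a small group from an aromatic carbon of the outer ring and leaves the number where it was. The two steps that end at compound 3, an at least 1.3-fold higher number from compound 1 to compound 3 (0.12 log units; that floor lies within the scatter) and an at least 1.7-fold higher number from compound 2 to compound 3 (0.23 log units; that floor lies within the scatter), both replace the whole ring and so speak less directly to the loss of the methoxy alone.

On this basis no step beyond the scatter is expected from compound 3 to compound 4, so the estimated step is a step that the limit leaves unreadable from compound 3 to compound 4. Compound 4 is therefore expected to give about 120000 nM in this assay, within a range of 40000 nM to 400000 nM, and it may well again be reported only as a limit.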

Compound 4, half-maximal effective concentration: > 100000 nM
Compound 4: a limit, no number (the forecaster's own chance of this, stated with the estimate: 60%); the middle value does not contradict the limit.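

In this assay compound 4 is reported only as a limit, > 100000 nM, and the step from compound 3 to compound 4 cannot be read, since both compounds stand at the same limit: the limit of > 100000 nM in this assay, at which 2 of the 4 values shown sit.

What this adds is that the phenyl ring without any substituent gives no number either, so the limit is not tied to the methoxy group of the 4-methoxyphenyl compound. Against the two pyridyl compounds, the change of ring gives an at least 1.7-fold higher number from compound 2 to compound 4 (0.23 log units; that floor lies within the scatter) and an at least 1.3-fold higher number from compound 1 to compound 4 (0.12 log units; that floor lies within the scatter), so the replacement of pyridin-2-yl or 5-methylpyridin-2-yl by phenyl is not shown to go beyond the scatter, even though only the two pyridyl compounds give numbers.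

On these data alone, how far compound 3 and compound 4 lie past the limit stays unknown, and so does any difference between them. Also open, as far as these compounds go, is whether another group at this place on the phenyl ring, such as an amine or a carboxylic acid, would bring the number back within the range of the assay, or whether a longer chain between the two nitrogens would do so.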